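Amide aryl swap: chloropyridinyl replacing chlorophenyl

A few compounds are considered here, and "the series" means these few. Any claim that something is new, unique, unknown or untested is made for them only; others in the source may bear on it.

Two analogues of the shared core are measured. Compound 1 `Cn1cc(-c2cnc(N)c(Oc3ccc(C(=O)Nc4ccccc4Cl)cc3)n2)cn1` gives 44800 nM in a functional assay on U-87MG ATCC cells for inhibition, with U-87 MG (Homo sapiens) as the target, read by MTT assay, with a stated time of 72 h; a lower number here means a stronger inhibitor, a higher number a weaker inhibitor. Compound 2 `Cn1cc(-c2cnc(N)c(Oc3ccc(C(=O)Nc4ccc(Cl)cc4)cc3)n2)cn1` gives 35800 nM in this assay. For the measured compounds named here, the only step between measured compounds, a 1.3-fold lower number from compound 1 to compound 2 (0.10 log units; within the scatter), is a move of the chlorine-bearing group on the amide-type nitrogen from 2-chlorophenyl to 4-chlorophenyl, and it stays within the scatter. Compound 2 therefore holds the lower of the two numbers, but it is not separated from compound 1 beyond the scatter, so no ordering is claimed.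

Compound 3 `Cn1cc(-c2cnc(N)c(Oc3ccc(C(=O)Nc4cccc(Cl)n4)cc3)n2)cn1` is not yet measured. It differs from compound 2 by 6-chloropyridin-2-yl in place of 4-chlorophenyl on an amide-type nitrogen. Going by the values given here, no measured step exchanges a ring carbon for a ring nitrogen on this group; the single step available, a 1.3-fold lower number from compound 1 to compound 2 (0.10 log units; within the scatter), only relocates the chlorine on an all-carbon ring and showed nothing beyond scatter. The data give no basis for a change beyond the scatter in this assay in either direction. The step of a 1.0-fold lower number from compound 2 to compound 3 (0.01 log units; within the scatter) is expected to sit within the scatter. Compound 3 is expected to give about 35000 nM, within a range of 12000 nM to 100000 nM.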

Compound 3, half-maximal inhibitory concentration: 54800 nM
For compound 3 the middle estimate is 1.6-fold (0.19 log units) below the measured one, within the range that was stated.
By their numbers in this assay, from the lowest: compounds 2, 1 and 3 (each within the scatter of the next).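

Replacing an all-carbon ring with a ring holding one hetero atom on the amide-type nitrogen now has a direct reading in this assay: 6-chloropyridin-2-yl for 4-chlorophenyl gives a 1.5-fold higher number from compound 2 to compound 3 (0.18 log units; within the scatter), and 6-chloropyridin-2-yl for 2-chlorophenyl gives a 1.2-fold higher number from compound 1 to compound 3 (0.09 log units; within the scatter). Both steps stay within the scatter, so the entering ring, with its one hydrogen-bond acceptor where the leaving groups count none, is not separated from either chlorophenyl group, and the three compounds carry no order at this position. No supporting information bears on this result, so nothing can be said about what lies behind it.

For the compounds shown here, all three compounds carry a chlorine-bearing aromatic ring on this nitrogen, so the series so far does not show whether any change here can produce a step beyond the scatter in this assay. Open questions include what an unsubstituted phenyl, a saturated cyclohexyl ring, or an aryl ring bearing an amine or a carboxylic acid would give at this place.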